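This account rests on a few compounds, and the source may have more. Where it says the series, first, only, none or still open, it means among the compounds named here.

Measured so far:
compound 1, `Cc1cccc(Cl)c1NC(=O)CN1CCC(c2ccccn2)CC1`, 70%
compound 2, `Cc1cc(Br)ccc1NC(=O)CN1CCC(c2cccc[n+]2[O-])CC1`, 61%

The study measures agonist response in a functional assay on HEK293 cells for agonist activity at D(4) dopamine receptor (Homo sapiens), read by FLIPR; a higher number here means a larger maximal response, a lower number a smaller maximal response. Compound 1 gives 70% in this assay, the higher of the two numbers shown, while compound 2 gives 61%; the gap between them lies within the scatter of repeated measurements, so the two cannot be ordered on these numbers.

Compound 3, `CCc1cccc(C)c1NC(=O)CN1CCC(c2ccccn2)CC1`, has not yet been measured in this assay. It differs from compound 1 in one place: ethyl in place of chloro on an aromatic carbon. Going by the values given here, no pair of measured compounds shows this change, so there is no measured step to lean on. Among the compounds with values here, both compounds measured so far give responses of similar size despite their different substituents on the aromatic ring, which gives no sign that a single change of this kind moves the response far.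

Compound 3 is therefore expected to give about 65% in this assay, with a range from 45% to 85%. The expected step of a number 5 percentage points lower from compound 1 to compound 3 (within the scatter) is estimated to be small, within the scatter, in no clear direction.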

Compound 3, largest response reached (reported as efficacy), in percent of the reference or control that the assay uses: 70%
Beside the measured number, compound 3's estimate is 5 percentage points below it, and the stated range covers the measured number.
By their numbers in this assay, from the lowest: compounds 2, 1 and 3 (each within the scatter of the next).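

Going by these compounds alone, the replacement of chloro by ethyl on an aromatic carbon, ortho to a large group and meta to a methyl group, is the first single change that can be read in this assay, and it shows no change at the digits printed from compound 1 to compound 3 (within the scatter). At this position, a group of 2 heavy atoms, both carbon, can therefore take the place of a single chlorine atom without the maximal response moving beyond the scatter, which the earlier pair, differing in more than one place, could not show. Nothing among the data shown bears on why the response holds across this change.

The compounds shown leave open whether the response would also hold with a different kind of group at this place, such as a methoxy group, an amine or a carboxylic acid, or with a longer chain such as propyl or butyl. Within the data shown here, they also leave open whether ethyl in place of chloro would give a similar step on another core, since this single pair is the only reading of the change.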